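Removing the cyclobutyl from the pyrazole amide of compound 2

The source may report more compounds than this note shows. Statements on the series, on what has been measured and on what is new or still open speak of the compounds shown alone.

In an assay on isolated protein for inhibition of cathepsin K (Rattus norvegicus) (on this read-out higher numbers stand for weaker inhibition and lower numbers for stronger inhibition), compound 2 `CCCC[C@H](NC(=O)OC(C(C)C)C(C)C)C(=O)C(=O)Nc1ccnn1C1CCC1` gives 1100 nM, the highest of the two numbers available; compound 1 `CCCC[C@H](NC(=O)OC(C(C)C)C(C)C)C(=O)C(=O)Nc1ccn(C)n1` gives 11 nM. Going by the values given here, the only measured step, a 100-fold higher number from compound 1 to compound 2 (2.00 log units; beyond the scatter), is the one that led to compound 2. Compound 3 `CCCC[C@H](NC(=O)OC(C(C)C)C(C)C)C(=O)C(=O)Nc1[nH]ncc1C` carries the change (4-methyl-1H-pyrazol-5-yl in place of 1-cyclobutyl-1H-pyrazol-5-yl on an amide-type nitrogen). Among the compounds with values here, no measured step covers this change directly, but since it removes the cyclobutyl whose introduction accompanied the large loss, a lower number is expected, though not the full return. Compound 3 is therefore estimated at 60 nM (range 8 nM to 400 nM), an expected step of an 18-fold lower number from compound 2 to compound 3 (1.26 log units; beyond the scatter).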

Compound 3, half-maximal inhibitory concentration: 5.5 nM
Compound 3: the middle estimate sits 11-fold (1.04 log units) above what was measured; measured number below the stated range.
By their numbers in this assay, from the lowest: compounds 3 and 1 (each within the scatter of the next); then compound 2.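

On the amide-type nitrogen, the 1-cyclobutyl-1H-pyrazol-5-yl group gives way to 4-methyl-1H-pyrazol-5-yl with a 200-fold lower number from compound 2 to compound 3 (2.30 log units; beyond the scatter) in this assay, so a pyrazol-5-yl group as such does not carry the high number of compound 2. With a 2.0-fold lower number from compound 1 to compound 3 (0.30 log units; within the scatter), two differently substituted pyrazoles on this nitrogen cannot be told apart. Nothing available explains these results.

On these data alone, the change removes the cyclobutyl and adds the methyl together, so their separate shares stay open. Also open, as far as these compounds go, is how a 1-methyl-1H-pyrazol-5-yl group or a carboxylic acid on the pyrazole would read.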